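A few compounds are considered here, and "the series" means these few. Any claim that something is new, unique, unknown or untested is made for them only; others in the source may bear on it.

Of the compounds shown here, two of the shared core have been measured in a functional assay on HOP-92 cells (Homo sapiens) for cytotoxicity, read by sulforhodamine B assay, with a stated time of 24 h; on this read-out lower numbers stand for stronger inhibition of growth and higher numbers for weaker inhibition of growth. Compound 1 `COc1ccc(C(=O)/C=C/c2cc3ccccc3[nH]c2=O)cc1` gives 2970 nM in this assay, and compound 2 `O=C(/C=C/c1cc2ccccc2[nH]c1=O)c1ccc(O)cc1` gives 3260 nM. The two numbers lie within the scatter of each other, so compound 2 cannot be set apart from compound 1 on this read-out and stands simply alongside it.

Compound 3 `O=C(/C=C/c1cc2ccccc2[nH]c1=O)c1ccc(Cl)cc1` is not yet measured. Against compound 2 the change is chloro in place of hydroxy on an aromatic carbon. Going by the values given here, only one measured step bears on this, a 1.1-fold higher number from compound 1 to compound 2 (0.04 log units; within the scatter), which concerns the same oxygen and stayed within the scatter. Among the compounds with values here, no measured pair replaces that oxygen by a chlorine, so the present step is only loosely anchored. The expectation is a number close to that of compound 2, with no step beyond the scatter in either direction, and the step to compound 3 is accordingly estimated as a 1.1-fold lower number from compound 2 to compound 3 (0.04 log units; within the scatter). Compound 3 is expected to give about 3000 nM in this assay, within a range of 1000 nM to 9000 nM, the width reflecting the absence of any closely matching measured step.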

Compound 3, concentration for 50% growth inhibition: 5740 nM
The estimate for compound 3 lay 1.9-fold (0.28 log units) below the measured number; the measured number falls inside the stated range.
By their numbers in this assay, from the lowest: compounds 1, 2 and 3 (each within the scatter of the next).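

In this assay the change from 4-hydroxyphenyl to 4-chlorophenyl gives a 1.8-fold higher number from compound 2 to compound 3 (0.25 log units; within the scatter) and the change from methoxy to chloro gives a 1.9-fold higher number from compound 1 to compound 3 (0.29 log units; within the scatter) and so neither step leaves the scatter. The earlier pair altered only what sits on the oxygen, whereas here the oxygen itself is gone, along with the hydrogen-bond donor and acceptor counted for hydroxy, and the position on the aromatic ring, para to a large group, still shows no step beyond the scatter among hydroxy, methoxy and chloro. No measurement bears on the reason for these numbers.

From the compounds shown here alone, with only these three groups at this place, it remains open whether any substituent there can move the number beyond the scatter, for example an amine, a carboxylic acid or a longer alkoxy chain. The shared core stays fixed in all three compounds, so the compounds shown say nothing about changes to the enone linker or to the ring system that carries it.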